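Methoxy in place of phenyl on a sulfonamide-linked benzylamine

This account rests on a few compounds, and the source may have more. Where it says the series, first, only, none or still open, it means among the compounds named here.

Measured compounds:
compound 1, `O=S(=O)(NCCCCNCc1ccc(Br)cc1)c1cc(C(F)(F)F)cc(C(F)(F)F)c1`, giving 1600 nM in a functional assay on HT-29 cells (Homo sapiens) for inhibition, read by MTT assay, with a stated time of 72 h; a lower number here means a stronger inhibitor of growth, a higher number a weaker inhibitor of growth
compound 2, `O=S(=O)(NCCCNCc1ccccc1)c1cc(C(F)(F)F)cc(C(F)(F)F)c1`, giving 15000 nM in this assay
compound 3, `O=S(=O)(NCCCNCc1ccc(-c2ccccc2)cc1)c1cc(C(F)(F)F)cc(C(F)(F)F)c1`, giving 2300 nM in this assay

Compound 3 stands second highest of the three numbers in this assay. Its nearest neighbour is compound 1, and the gap between them lies within the scatter; its furthest is compound 2, with a step of a 6.5-fold lower number from compound 2 to compound 3 (0.81 log units; beyond the scatter) that lies beyond the scatter.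

Compound 4, `COc1ccc(CNCCCNS(=O)(=O)c2cc(C(F)(F)F)cc(C(F)(F)F)c2)cc1`, differs from compound 3 in one place: methoxy in place of phenyl on an aromatic carbon. Among the measured compounds shown here, the step that bears on this is the one from compound 2 to compound 3, where phenyl entered in place of hydrogen at the same aromatic carbon and the number fell by a 6.5-fold lower number from compound 2 to compound 3 (0.81 log units; beyond the scatter). The other step, a 9.4-fold higher number from compound 1 to compound 2 (0.97 log units; beyond the scatter), alters both the halogen on that ring and the chain length, so it speaks less directly. No compound carries methoxy at this position, so the size of its effect is not shown; a group smaller than phenyl but larger than hydrogen might be expected to land between compounds 2 and 3.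

Compound 4 is therefore expected to give about 5000 nM in this assay, within 2000 nM to 14000 nM, a step of a 2.2-fold higher number from compound 3 to compound 4 (0.34 log units; beyond the scatter) toward a weaker inhibitor of growth.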

Compound 4, concentration for 50% growth inhibition: 2900 nM
Compound 4: the middle estimate sits 1.7-fold (0.24 log units) above what was measured; low and high end bracket the measured number.
By their numbers in this assay, from the lowest: compounds 1, 3 and 4 (each within the scatter of the next); then compound 2.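

In this assay, the step of a 1.3-fold higher number from compound 3 to compound 4 (0.10 log units; within the scatter) stays within the scatter, so at this aromatic carbon, para to a large group, the phenyl ring is not required to keep the number at this level: methoxy, which has no ring, serves as well. Measured against hydrogen at the same carbon, methoxy gives a 5.2-fold lower number from compound 2 to compound 4 (0.71 log units; beyond the scatter), and phenyl gives a 6.5-fold lower number from compound 2 to compound 3 (0.81 log units; beyond the scatter), so two very different groups each stand clear of the unsubstituted compound 2 by steps beyond the scatter. The step of a 1.8-fold higher number from compound 1 to compound 4 (0.26 log units; within the scatter) also stays within the scatter, though it spans a change of chain as well as of the group on the ring, and no measurement at hand accounts for any of these numbers.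

The compounds shown leave open whether a hydroxyl, a fluorine or a dimethylamino group at this carbon would also stand with compound 3 and compound 4, or would fall back toward compound 2. They also leave open what a bromine on the ring would do with the chain of compound 4, or a longer chain with its methoxy, so the parts played by chain and ring group in compound 1 stay unseparated.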